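The source may report more compounds than this note shows. Statements on the series, on what has been measured and on what is new or still open speak of the compounds shown alone.

Of the compounds shown here, two built on the same core have been measured so far. Compound 1 `O=C1/C(=C/c2ccccc2)NS(=O)(=O)c2ccccc21` gives 1780 nM in an assay for inhibition of Intestinal-type alkaline phosphatase (Homo sapiens), read by spectrophotometry, with stated times of 10 min and 20 min; a lower number here means a stronger inhibitor, a higher number a weaker inhibitor. Compound 2 `O=C1/C(=C/c2ccc(Cl)cc2)NS(=O)(=O)c2ccccc21`, which carries a chloro in place of hydrogen on an aromatic carbon, gives 4350 nM in this assay; the step of a 2.4-fold higher number from compound 1 to compound 2 (0.39 log units; beyond the scatter) is modest but real. Going by the values given here, of the two numbers so far, compound 2 stands highest, that is, it is the weaker inhibitor of the pair, with compound 1 as its only neighbour.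

Compound 3 `O=C1/C(=C/c2cccc(F)c2)NS(=O)(=O)c2ccccc21` has not yet been measured. Its change from compound 2 is 3-fluorophenyl in place of 4-chlorophenyl on a double-bonded chain carbon bound to a double-bonded ring carbon. Among the compounds with values here, only one measured step bears on this: a 2.4-fold higher number from compound 1 to compound 2 (0.39 log units; beyond the scatter), which shows that adding a chloro to the plain phenyl of compound 1 weakened inhibition. Within the data shown here, compound 3 removes that chloro and instead carries a 3-fluorophenyl; no measured compound carries fluorine, so the effect of the fluorine itself is unknown. Taking the loss of the chloro as the better-founded part of the change, the expected step is estimated as a 1.7-fold lower number from compound 2 to compound 3 (0.24 log units; within the scatter), pointing back toward stronger inhibition. The estimate for compound 3 in this assay is 2500 nM, with a range from 1000 nM to 6000 nM.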

Compound 3, half-maximal inhibitory concentration: 9930 nM
Estimate against measurement, compound 3: 4.0-fold (0.60 log units) below, outside the stated range (above it).
By their numbers in this assay, from the lowest: compound 1; then compound 2; then compound 3.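

Adding a fluoro to the phenyl does not bring inhibition back toward compound 1. In this assay the swap of 4-chlorophenyl for 3-fluorophenyl gives a 2.3-fold higher number from compound 2 to compound 3 (0.36 log units; beyond the scatter), and measured against the plain phenyl the fluoro gives a 5.6-fold higher number from compound 1 to compound 3 (0.75 log units; beyond the scatter). Among these three compounds, then, both substituted rings on the double-bonded chain carbon give weaker inhibition than the unsubstituted phenyl, no compound shown goes against this, and compound 3 is the weakest of the set, with its steps to both others beyond the scatter. Nothing available here bears on the reason for this order.

The change from compound 2 to compound 3 alters both the halogen and its place on the ring at once, so these numbers cannot separate the two, whereas a 3-chlorophenyl or a 4-fluorophenyl on the same carbon would pull them apart. Also open, from the compounds shown here alone, is whether every group on this phenyl raises the number, or whether a hydroxyl, a methoxy or an amine there would match or improve on the plain phenyl of compound 1.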